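Three limits in one ether side-chain series, and a fourth member

The source may hold more compounds than are shown below. What is called first, only, known or untested is meant among the compounds shown, and "the series" means these compounds.

Measured so far:
compound 1, `COCCOCCOc1cccc2ccc(N)nc12`, > 2000 nM
compound 2, `Nc1ccc2cccc(OCC3CCCO3)c2n1`, > 2000 nM
compound 3, `CC#CCCOc1cccc2ccc(N)nc12`, > 2000 nM

In an assay on cells with melanin-concentrating hormone receptor 1 (Homo sapiens) as the target, read by radioligand binding (a higher number here means a weaker inhibitor, a lower number a stronger inhibitor), compound 1 gives > 2000 nM, a limit of the assay rather than a number. Compound 2 likewise gives a limit, > 2000 nM. Compound 3 also gives a limit, > 2000 nM. The steps among these three are a step that the two limits leave unreadable from compound 1 to compound 2, a step that the two limits leave unreadable from compound 1 to compound 3 and a step that the two limits leave unreadable from compound 2 to compound 3: none has a readable size. The common picture is the limit of > 2000 nM in this assay, at which 3 of the 3 values shown sit.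

Compound 4, `Nc1ccc2cccc(OCC3CCOC3)c2n1`, is the next member. It differs from compound 1 in the side chain: oxolan-3-yl in place of (2-methoxyethoxy)methyl on a saturated chain carbon bound to an oxygen on an aromatic ring. The bearing steps are those from compound 1 to its two analogs, both unreadable, so no direction or size beyond the scatter can be derived; compound 2 carries the closest side chain and sits at the limit too.

For compound 4 the expected value in this assay is 4000 nM, with a range of 1500 nM to 12000 nM, most likely reported only as a limit because the limit of > 2000 nM in this assay, at which 3 of the 3 values shown sit, holds for every analog so far. The estimated step is a step that the limit leaves unreadable from compound 1 to compound 4.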

Compound 4, half-maximal inhibitory concentration: 115 nM
For compound 4 the middle estimate is 35-fold (1.54 log units) above the measured one; measured number below the stated range.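

At the saturated chain carbon bound to an oxygen on an aromatic ring, the side chain does separate compounds in this assay: oxolan-3-yl gives an at least 17-fold lower number from compound 1 to compound 4 (1.24 log units; beyond the scatter) and an at least 17-fold lower number from compound 3 to compound 4 (1.24 log units; beyond the scatter). Oxolan-3-yl in place of oxolan-2-yl gives an at least 17-fold lower number from compound 2 to compound 4 (1.24 log units; beyond the scatter), so the presence of an oxolane ring is not enough on its own, as compound 2 carries one and stays at its limit. Compound 4 is the only compound here that stands clear of the common picture: the limit of > 2000 nM in this assay, at which 3 of the 4 values shown sit.

The steps among compound 1, compound 2 and compound 3 cannot be read, so no order among those three can be given. Also open, from the compounds shown here alone, is whether the lower number at compound 4 holds with a pyrrolidin-3-yl amine or a six-membered oxan-3-yl ring in place of oxolan-3-yl.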